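The compounds below may be only part of what the source reports. "The series", "measured", "known", "first", "only" and "open" are said of these compounds alone.

Measured in a functional assay on HepG2 cells (Homo sapiens) for antiproliferative activity, read by MTT assay, with a stated time of 72 h; a lower number here means a stronger inhibitor, a higher number a weaker inhibitor:
compound 1 `O=C1O[C@H]([C@@H](O)Cn2cc(-c3cc(C(F)(F)F)cc(C(F)(F)F)c3)nn2)C(OCc2ccccc2)=C1OCc1ccccc1` — 33800 nM
compound 2 `O=C1O[C@H]([C@@H](O)Cn2cc(-c3cccc(O)c3)nn2)C(OCc2ccccc2)=C1OCc1ccccc1` — 62700 nM
compound 3 `COc1ccc(-c2cn(C/C=C3\OC(=O)C(OCc4ccccc4)=C3OCc3ccccc3)nn2)cc1` — > 100000 nM

Two numbers and one limit are in hand. In this assay compound 2 gives 62700 nM, and compound 1 gives 33800 nM; the gap between them lies within the usual scatter, so neither is set apart. For compound 3 the assay reports only a limit (the limit of > 100000 nM in this assay, at which 1 of the 3 values shown sits).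

Compound 4 `O=C1O[C@H]([C@@H](O)Cn2cc(-c3cc(F)cc(F)c3)nn2)C(OCc2ccccc2)=C1OCc1ccccc1` is not yet measured. It differs from compound 2 by 3,5-difluorophenyl in place of 3-hydroxyphenyl on an aromatic carbon. Among the measured compounds shown here, no measured pair shows this change on its own, so the expected step of a 1.6-fold lower number from compound 2 to compound 4 (0.20 log units; within the scatter) is taken as small, toward a slightly lower number, and not beyond the scatter. Compound 4 is therefore expected at about 40000 nM, with a range from 15000 nM to 100000 nM.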

Compound 4, half-maximal inhibitory concentration: 11600 nM
For compound 4 the middle estimate is 3.4-fold (0.54 log units) above the measured one; the whole stated range lies above it.
By their numbers in this assay, from the lowest: compound 4; then compounds 1 and 2 (each within the scatter of the next). At a limit, above all of these: compound 3.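

Among the compounds shown here, the aryl group on the five-membered aromatic ring with 3 nitrogen is not a silent position: in this assay, 3,5-difluorophenyl in place of 3-hydroxyphenyl gives a 5.4-fold lower number from compound 2 to compound 4 (0.73 log units; beyond the scatter), the only measured single-place step so far. The entering group carries no hydrogen-bond donor or acceptor, whereas the leaving group carries one of each, but no measurement shown explains the step.

Open, going by these compounds, is whether one fluorine, as in 3-fluorophenyl, would give a similar number. Also open, on these data alone, is how an amine or a carboxylic acid on this aryl ring would read.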